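The source may hold more compounds than are shown below. What is called first, only, known or untested is meant among the compounds shown, and "the series" means these compounds.

Working notes on a small set sharing one core, varied at the group on a saturated chain carbon bound to a nitrogen on an aromatic ring, and in how the core atoms are joined.

Compound 1 `Cc1cc(Oc2ccc(Cn3nc4ccc(Cl)cc4c3C(=O)NS(=O)(=O)c3ccc(NCc4ccn(C)n4)c([N+](=O)[O-])c3)cc2)cc(C)c1Cl` carries 1-methyl-1H-pyrazol-3-yl at that place; in an assay on isolated protein for inhibition of Apoptosis regulator Bcl-2 (Homo sapiens), read by fluorescence polarization (a lower number here means a stronger inhibitor, a higher number a weaker inhibitor), compound 1 gives 600 nM. Compound 2 `Cc1cc(Oc2ccc(Cn3nc4ccc(Cl)cc4c3C(=O)NS(=O)(=O)c3ccc(NCc4cccnc4)c([N+](=O)[O-])c3)cc2)cc(C)c1Cl` differs from compound 1 by pyridin-3-yl in place of 1-methyl-1H-pyrazol-3-yl on a saturated chain carbon bound to a nitrogen on an aromatic ring; in this assay compound 2 gives 1180 nM. The resulting step is a 2.0-fold higher number from compound 1 to compound 2 (0.29 log units; within the scatter). Compound 3 `Cc1cc(Oc2ccc(Cn3nc4ccc(Cl)cc4c3C(=O)NS(=O)(=O)c3ccc([N+](=O)[O-])c(NCc4ccn(C)n4)c3)cc2)cc(C)c1Cl` has the same atoms as compound 1, joined differently; the difference between the two cores is not broken down here. In this assay compound 3 gives 710 nM, a number that sits within the scatter of both compound 1 and compound 2, so no ordering among the three is read from it.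

Compound 4 `Cc1cc(Oc2ccc(Cn3nc4ccc(Cl)cc4c3C(=O)NS(=O)(=O)c3ccc([N+](=O)[O-])c(NCc4cccnc4)c3)cc2)cc(C)c1Cl` is not yet measured. It differs from compound 3 by pyridin-3-yl in place of 1-methyl-1H-pyrazol-3-yl on a saturated chain carbon bound to a nitrogen on an aromatic ring, the same change that separates compound 2 from compound 1, at the same place on the other core. Among the measured compounds shown here, with only one prior instance of this change, the earlier 2.0-fold higher number from compound 1 to compound 2 (0.29 log units; within the scatter) is the sole guide, and a step of about the same size is expected on the core of compound 3. On that footing the expected step is a 2.0-fold higher number from compound 3 to compound 4 (0.29 log units; within the scatter). Compound 4 is therefore estimated at 1400 nM in this assay, with a likely range from 700 nM to 2800 nM.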

Compound 4, inhibition constant: 1220 nM
Compound 4: middle estimate off by 1.1-fold (0.06 log units), on the high side, and the stated range covers the measured number.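

In this assay, pyridin-3-yl in place of 1-methyl-1H-pyrazol-3-yl on the core of compound 3 gives a 1.7-fold higher number from compound 3 to compound 4 (0.24 log units; within the scatter), and this step agrees with the one seen on the core of compound 1: the same change on two cores in this assay, a 2.0-fold higher number (0.29 log units; within the scatter) from compound 1 to compound 2 and a 1.7-fold higher number (0.24 log units; within the scatter) from compound 3 to compound 4, 1.1-fold (0.06 log units) apart, within the scatter of two such steps. As far as these two pairs can tell, the change carries from one core to the other with no detectable difference in the size of the step, so the step on one core served as a fair guide to the step on the other. This does not show that the change has a real effect in this assay, as each step on its own lies within the scatter, and two cores cannot stand for the whole series.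

The compounds shown leave open whether another group at this place, such as a phenyl ring, a morpholine or a longer alkyl chain, would give a step beyond the scatter on either core. They also leave open whether the agreement between the two steps would hold for a change large enough to stand clear of the scatter, or in any other read-out.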